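Pyridin-2-ylmethyl in place of 3-fluorobenzyl: expected cytotoxicity

The compounds below may be only part of what the source reports. "The series", "measured", "known", "first", "only" and "open" are said of these compounds alone.

The series shares one core and differs only at the substituent on the amide-type nitrogen in the ring. Compound 1 `CS(=O)(=O)Nc1ccc2c(c1)S(=O)(=O)N=C(C1=C(O)C3CCCC3N(C3CCCCC3)C1=O)N2` carries a cyclohexyl there, compound 2 `CS(=O)(=O)Nc1ccc2c(c1)S(=O)(=O)N=C(C1=C(O)C3CCCC3N(C3CCCC3)C1=O)N2` a cyclopentyl, and compound 3 `CS(=O)(=O)Nc1ccc2c(c1)S(=O)(=O)N=C(C1=C(O)C3CCCC3N(Cc3cccc(F)c3)C1=O)N2` a 3-fluorobenzyl. In an ADME assay on Huh-7 cells (Homo sapiens) for cytotoxicity, with a stated time of 72 h (on this read-out higher numbers stand for lower toxicity in this test and lower numbers for higher toxicity in this test), compound 1 gives > 10000 nM, which is a limit of the assay and not a number. For compound 2 the outcome in this assay is "not determined" (no result reported). In this assay compound 3 gives > 33000 nM, again a limit rather than a number, so compound 3 stands at one of two limits of the assay, with no single number anywhere in the set. The step that the two limits leave unreadable from compound 1 to compound 3 is therefore unreadable between the limits the limit of > 10000 nM in this assay, at which 1 of the 3 values shown sits, and (the limit of > 33000 nM in this assay, at which 1 of the 3 values shown sits).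

Compound 4 `CS(=O)(=O)Nc1ccc2c(c1)S(=O)(=O)N=C(C1=C(O)C3CCCC3N(Cc3ccccn3)C1=O)N2` differs from compound 3 by pyridin-2-yl in place of 3-fluorophenyl on a saturated chain carbon bound to an amide-type nitrogen in a ring. With no readable measured step bearing on this change, the expectation for compound 4 in this assay is a step that the limit leaves unreadable from compound 3 to compound 4 of no clear size, and compound 4 is estimated at 50000 nM, within 20000 nM to 120000 nM.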

Compound 4, half-maximal cytotoxic concentration: > 33000 nM
Compound 4: no number, only a limit (the forecaster's own chance of this, stated with the estimate: 80%); the middle value is on the limit's open side.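

In this assay, for the compounds shown here, compound 1, compound 3 and compound 4 each give only a limit of the assay and not a number, so no step among them can be read. The compounds shown leave open whether changing the substituent on the amide-type nitrogen in the ring shifts the half-maximal cytotoxic concentration at all.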